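Removing the nitrogen-bearing group from the shared core

The compounds below may be only part of what the source reports. "The series", "measured", "known", "first", "only" and "open" are said of these compounds alone.

Of the compounds shown here, two with a shared core have been measured in an assay on isolated protein for binding affinity to Alpha-1D adrenergic receptor (Rattus norvegicus), read by radioligand binding; a higher number here means a weaker inhibitor, a lower number a stronger inhibitor. Compound 1 `O=S(=O)(Nc1cccc2c1CCCC2c1c[nH]cn1)C1CC1` gives 2690 nM in this assay, and compound 2 `COC(=O)Nc1cccc2c1CCCC2c1c[nH]cn1` gives 3020 nM. The single step between them, a 1.1-fold higher number from compound 1 to compound 2 (0.05 log units; within the scatter), lies within the scatter, so compound 2 stands alongside compound 1, the two values indistinguishable on the numbers shown. Compound 3 `Oc1cccc2c1CCCC2c1c[nH]cn1` has not been measured. It differs from compound 2 in one place: hydroxy in place of (methoxycarbonyl)amino on an aromatic carbon. Among the compounds with values here, no measured step bears directly on this change. Within the data shown here, the one known step exchanged cyclopropylsulfonyl for methoxycarbonyl on the nitrogen and stayed within the scatter, which says nothing about what follows when the whole (methoxycarbonyl)amino group gives way to hydroxy. With no guide in either direction, compound 3 is expected to land near compound 2, the step of a 1.0-fold lower number from compound 2 to compound 3 (0.00 log units; within the scatter) being the expectation, with a wide allowance on both sides. The estimate for compound 3 in this assay is 3000 nM, expected to fall between 900 nM and 10000 nM.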

Compound 3, inhibition constant: 30.9 nM
Estimate against measurement, compound 3: 97-fold (1.99 log units) above; the measured number lies below the stated range.
By their numbers in this assay, from the lowest: compound 3; then compounds 1 and 2 (each within the scatter of the next).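

In this assay, within the data shown here, the earlier pair showed only that the group on the nitrogen could be exchanged with no change beyond the scatter, whereas replacing the whole substituent on this aromatic carbon gives a 98-fold lower number from compound 2 to compound 3 (1.99 log units; beyond the scatter) for hydroxy in place of (methoxycarbonyl)amino and an 87-fold lower number from compound 1 to compound 3 (1.94 log units; beyond the scatter) for hydroxy in place of (cyclopropylsulfonyl)amino. These two large steps start from values within the scatter of each other and end at the same compound, so the result does not depend on which of the two nitrogen-linked groups leaves, and this aromatic carbon proves far from indifferent to what it carries. Nothing available accounts for the size of the change from these larger groups to hydroxy, with its single heavy atom.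

Going by these compounds, it remains open whether the gain belongs to hydroxy itself or follows from the loss of the nitrogen-linked groups, a question that a plain amine, a methoxy group or a bare hydrogen on this carbon would help to settle. Also open is whether hydroxy would have a like effect on another carbon of the same aromatic ring, since the compounds shown carry their substituent in only this one place.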